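Swapping the Aryl Group on the Pyrazole Core

A few compounds are considered here, and "the series" means these few. Any claim that something is new, unique, unknown or untested is made for them only; others in the source may bear on it.

Measured so far:
Compound 1 `Cc1c(-c2cc(Cl)cc(Cl)c2)c(C(=O)O)nn1-c1nc(-c2cc(Cl)cc(Cl)c2)c(SC(C)C)s1`: 2000 nM
Compound 2 `COc1ccccc1-c1c(C)nn(-c2nc(-c3ccc(Cl)c(Cl)c3)c(SC(C)C)s2)c1C(=O)O`: 14700 nM
Compound 3 `Cc1c(-c2cc(Cl)cc(Cl)c2)c(C(=O)O)nn1-c1nc(-c2ccc3nccn3c2)c(SC(C)C)s1`: "not active" (no number reported), with no number given

In a functional assay on BJAB cells (Homo sapiens) for antiproliferative activity, with a stated time of 4 days (on this read-out lower numbers stand for an effect already at smaller amounts and higher numbers for an effect only at larger amounts of compound), compound 2 gives 14700 nM, the highest of the two numbers; compound 1 gives 2000 nM, a gap that lies beyond the usual scatter. Compound 3 is reported as "not active" (no number reported) and returned no number at all.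

Compound 4 `Cc1nn(-c2nc(-c3ccc(Cl)c(Cl)c3)c(SC(C)C)s2)c(C(=O)O)c1-c1ccc(Cl)cc1` differs from compound 2 in one place: 4-chlorophenyl in place of 2-methoxyphenyl on an aromatic carbon. The change drops the single hydrogen-bond acceptor of the leaving group. Among the compounds with values here, no directly comparable pair has been measured, so the expected step from compound 2 to compound 4 is a 2.9-fold lower number from compound 2 to compound 4 (0.47 log units; beyond the scatter), a modest move toward smaller amounts, since compound 1, which also carries chlorine-bearing rings, gives 2000 nM. Compound 4 is therefore estimated at 5000 nM, with a range from 1500 nM to 15000 nM.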

Compound 4, half-maximal effective concentration: 2500 nM
For compound 4 the middle estimate is 2.0-fold (0.30 log units) above the measured one, within the range that was stated.
By their numbers in this assay, from the lowest: compounds 1 and 4 (each within the scatter of the next); then compound 2.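

In this assay, the group on this aromatic carbon of the pyrazole core clearly affects the result: 4-chlorophenyl in place of 2-methoxyphenyl gives a 5.9-fold lower number from compound 2 to compound 4 (0.77 log units; beyond the scatter) with the rest of the molecule unchanged. Within the data shown here, this is the first comparison that differs in one place only, so it isolates this position. Nothing measured here explains the step. On these data alone, the swap changes both the substituent and where it sits on the phenyl ring, so which of these matters remains open. As far as these compounds go, how a plain phenyl or a phenyl bearing an amine would compare is also open.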